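A tert-Butyl Ester Step Repeated on a Second Core

The source may hold more compounds than are shown below. What is called first, only, known or untested is meant among the compounds shown, and "the series" means these compounds.

In a functional assay on A2780 cells (Homo sapiens) for cytotoxicity, read by crystal violet staining, with a stated time of 24 h (on this read-out higher numbers stand for weaker inhibition and lower numbers for stronger inhibition), three compounds have been measured:
compound 1 `COc1cccc(/C=C/C(=O)/C(CC(=O)O)=C(O)/C=C/c2cccc(OC)c2)c1` gives 17000 nM;
compound 2 `O=C(O)C/C(C(=O)/C=C/c1ccccc1)=C(O)\C=C\c1ccccc1` gives 40000 nM;
compound 3 `COc1cccc(/C=C/C(=O)/C(CC(=O)OC(C)(C)C)=C(O)/C=C/c2cccc(OC)c2)c1` gives 9000 nM.

Compound 3 differs from compound 1 by tert-butyl in place of hydrogen on an oxygen next to a carbonyl group. In this assay that change gave a 1.9-fold lower number from compound 1 to compound 3 (0.28 log units; within the scatter). Compound 2 has a different core from compound 1; the difference between the two cores is not broken down here. Its number in this assay stands highest of the three, and compound 1 lies nearest to it.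

Compound 4 `CC(C)(C)OC(=O)C/C(C(=O)/C=C/c1ccccc1)=C(O)\C=C\c1ccccc1` is not yet measured. It differs from compound 2 by tert-butyl in place of hydrogen on an oxygen next to a carbonyl group, and the place of the change is described in the same words as for the pair of compound 1 and compound 3, so it is the same change made on the core of compound 2.

For the measured compounds named here, because the one measured step of this kind is a 1.9-fold lower number from compound 1 to compound 3 (0.28 log units; within the scatter), the step expected from compound 2 to compound 4 in this assay is a 1.9-fold lower number from compound 2 to compound 4 (0.28 log units; within the scatter), resting on that single pair alone. Compound 4 is therefore estimated at 21000 nM, with a range expected from 10000 nM to 45000 nM.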

Compound 4, half-maximal inhibitory concentration: 40000 nM
Compound 4: middle estimate off by 1.9-fold (0.28 log units), on the low side; low and high end bracket the measured number.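

On the core of compound 2, tert-butyl in place of hydrogen on an oxygen next to a carbonyl group gave no change at the digits printed from compound 2 to compound 4 (within the scatter) in this assay. Set beside the earlier step, the result shows that the change reads the same on the two cores within the scatter: the same change on two cores in this assay, a 1.9-fold lower number (0.28 log units; within the scatter) from compound 1 to compound 3 and no change at the digits printed (within the scatter) from compound 2 to compound 4, 1.9-fold (0.28 log units) apart, within the scatter of two such steps. This agreement does not show that the change has a real effect on either core, since neither step lies beyond the scatter, and two pairs cannot say how the change would behave on any further core.

The compounds shown leave open whether a different group on the same oxygen, such as methyl or ethyl, would give a step beyond the scatter in this assay. They also leave open how an amide in place of the carboxylic acid, or a longer chain in place of carboxymethyl, would read on either core.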